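Amino to ethyl on the aryl ring of compound 1

A few compounds are considered here, and "the series" means these few. Any claim that something is new, unique, unknown or untested is made for them only; others in the source may bear on it.

Measured so far:
compound 1, `COC(=O)C1=C(C)N=C(C)/C(=C(\O)OC)C1c1ccccc1N`, 39800 nM
compound 2, `COC(=O)C1=C(C)N=C(C)/C(=C(\O)OC)C1c1c(F)c(F)c(F)c(F)c1F`, 4.37 nM
compound 3, `COC(=O)C1=C(C)N=C(C)/C(=C(\O)OC)C1c1cccc([N+](=O)[O-])c1`, 3.98 nM

All three share one core and differ only in the aryl group. In a functional assay (muscle tissue) with Cavia porcellus as the target (a higher number here means that more compound is needed for the effect, a lower number that less compound is needed), compound 1 gives 39800 nM, the highest of the three numbers. Compound 2 gives 4.37 nM and compound 3 gives 3.98 nM; each of them stands far below compound 1, beyond the scatter, while the two of them lie within the scatter of each other and are not ordered.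

Compound 4, `CCc1ccccc1C1C(C(=O)OC)=C(C)N=C(C)/C1=C(\O)OC`, has not been measured. Against compound 1 the change is ethyl in place of amino on an aromatic carbon. Among the compounds with values here, no measured pair shows this change, so the expectation rests only on the wide gap between compound 1 and the other two. Compound 1 stands apart with 39800 nM, and the step of a 100-fold lower number from compound 1 to compound 4 (2.00 log units; beyond the scatter) is expected to be large and downward, toward the range of compound 2 and compound 3 without fully reaching it. For compound 4 the estimate is 400 nM, with a range from 40 nM to 4000 nM.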

Compound 4, half-maximal effective concentration: 6.46 nM
The estimate for compound 4 lay 62-fold (1.79 log units) above the measured number; measured number below the stated range.
By their numbers in this assay, from the lowest: compounds 3, 2 and 4 (each within the scatter of the next); then compound 1.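

In this assay, within the data shown here, the replacement of amino by ethyl on the aromatic carbon, ortho to a large group, is the first single-place change (a 6200-fold lower number from compound 1 to compound 4 (3.79 log units; beyond the scatter)). The step shows that this place tolerates a substituent: the high number of compound 1 goes with the amino group, not with the mere presence of a group there. Nothing on hand accounts for the size of the step.

Still open, from the compounds shown here alone, is how much of the step depends on the carbon chain itself, which methyl, propyl or a longer chain at the same place would test. Also open, going by these compounds, is whether a methoxy group, a hydroxyl group or a dimethylamino group there would give a number nearer to compound 1 or to compound 4.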